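The compounds below may be only part of what the source reports. "The series", "measured", "known", "first", "only" and "open" are said of these compounds alone.

In an ADME assay on the whole organism for cytotoxicity, with Artemia salina as the target, with a stated time of 24 h (on this read-out lower numbers stand for an effect already at smaller amounts and higher numbers for an effect only at larger amounts of compound), three compounds have been measured:

compound 1 `COc1ccc(/C=C/C(=O)c2ccccc2NC(=O)NS(=O)(=O)c2ccc(C)cc2)cc1` — 28.1 ug/mL
compound 2 `Cc1ccc(S(=O)(=O)NC(=O)Nc2ccccc2C(=O)/C=C/c2ccccc2O)cc1` — 32.3 ug/mL
compound 3 `Cc1ccc(S(=O)(=O)NC(=O)Nc2ccccc2C(=O)/C=C/c2cccc([N+](=O)[O-])c2)cc1` — 44.5 ug/mL

Compound 1 shows the lowest of these three numbers, yet none of the steps among them leaves the scatter: a 1.1-fold higher number from compound 1 to compound 2 (0.06 log units; within the scatter), a 1.6-fold higher number from compound 1 to compound 3 (0.20 log units; within the scatter) and a 1.4-fold higher number from compound 2 to compound 3 (0.14 log units; within the scatter). All three measured compounds share one core and differ only in the aryl group on the double-bonded chain carbon, and exchanging that group moved the read-out hardly at all.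

Compound 4 `Cc1ccc(S(=O)(=O)NC(=O)Nc2ccccc2C(=O)/C=C/C=C/c2ccccc2)cc1` is not yet measured. It departs from compound 1 by 2-phenylethenyl in place of 4-methoxyphenyl on a double-bonded chain carbon bound to a double-bonded chain carbon. The change sits at the same place as the three measured exchanges, so those steps are the ones that bear on it, and each of them stayed within the scatter. The new group is a chain rather than a substituted ring, so the precedent is less direct, but nothing in the data points to a shift in either direction. He therefore expects a step of a 1.1-fold higher number from compound 1 to compound 4 (0.06 log units; within the scatter), within the scatter. His estimate for compound 4 is 32 ug/mL, with a range from 16 ug/mL to 64 ug/mL.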

Compound 4, concentration for half-maximal effect: 18.2 ug/mL
Beside the measured number, compound 4's estimate is 1.8-fold (0.25 log units) above it; low and high end bracket the measured number.
By their numbers in this assay, from the lowest: compounds 4, 1, 2 and 3 (each within the scatter of the next, the first and the last beyond it).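

In this assay, this place, on a double-bonded chain carbon bound to a double-bonded chain carbon, now gives its first step beyond the scatter (a 2.4-fold lower number from compound 3 to compound 4 (0.39 log units; beyond the scatter)), a modest one, with 2-phenylethenyl entering for 3-nitrophenyl. The same group stays within the scatter of the other two groups (a 1.5-fold lower number from compound 1 to compound 4 (0.19 log units; within the scatter); a 1.8-fold lower number from compound 2 to compound 4 (0.25 log units; within the scatter)), so a ring set further out on a chain fits the same narrow band of numbers, and only compound 3 and compound 4 separate. Nothing in the data given explains that separation.

The compounds shown leave open whether a longer chain, such as one more double-bonded unit before the ring, would extend this step. They also leave open whether an amine or a carboxylic acid on the ring of 2-phenylethenyl would keep the number in this band.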